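The source may hold more compounds than are shown below. What is called first, only, known or untested is meant among the compounds shown, and "the series" means these compounds.

In an ADME assay on THP-1 cells (Homo sapiens) for cytotoxicity (a higher number here means that more compound is tolerated, a lower number that less compound is tolerated), compound 1 `O=C(Nc1ccc(C(F)(F)F)cc1)c1c(NC(=O)C(F)(F)F)sc2c1CCCCC2` gives 17200 nM and compound 3 `O=C(Nc1ccc(OC(F)(F)F)cc1)c1c(NC(=O)C(F)(F)F)sc2c1CCCCC2` gives 11900 nM. Going by the values given here, the single measured step is a 1.4-fold lower number from compound 1 to compound 3 (0.16 log units; within the scatter), which places compound 1 level with compound 3 and leaves no separation between the two numbers. Compound 2 `COc1ccc(NC(=O)c2c(NC(=O)C(F)(F)F)sc3c2CCC3)cc1` reads > 50000 nM, which is a limit of the assay and not a number.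

The next change leads to compound 4 `CC(C)(C)NC(=O)c1c(NC(=O)C(F)(F)F)sc2c1CCCCC2`: tert-butyl in place of 4-(trifluoromethyl)phenyl on an amide-type nitrogen, with the count (tert-butyl in place of 4-(trifluoromethyl)phenyl on an amide-type nitrogen). The measured step offers only indirect guidance, as it swaps one group on an aromatic carbon and leaves that ring in place, whereas here the whole ring leaves. Among the compounds with values here, no measured step replaces the group on the amide-type nitrogen with a group that has no ring, so the size of this step is poorly constrained. The lean towards a higher number in this assay rests on compound 2 alone, with its reading of > 50000 nM. The reachable range is closed off by the limit of > 50000 nM in this assay, at which 1 of the 3 values shown sits, so a reported limit is a real possibility.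

A moderate move is expected, estimated as a 1.7-fold higher number from compound 1 to compound 4 (0.24 log units; within the scatter). Compound 4 is estimated at 30000 nM, with an expected range of 13000 nM to 50000 nM.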

Compound 4, half-maximal cytotoxic concentration: > 50000 nM
Compound 4 ended at the assay's limit; the forecaster's own chance of this, stated with the estimate: 35%; middle value at least 1.6-fold (0.22 log units) away from the limit.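

Going by these compounds alone, on the amide-type nitrogen, tert-butyl in place of 4-(trifluoromethyl)phenyl gives the first step in this assay that lies beyond the scatter: an at least 2.9-fold higher number from compound 1 to compound 4 (0.46 log units; beyond the scatter). The earlier step, a 1.4-fold lower number from compound 1 to compound 3 (0.16 log units; within the scatter), swapped only a group on an aromatic carbon and kept the ring, whereas this change removes the ring and shows that the series can respond at this position by more than the scatter. For compound 4, > 50000 nM is a limit of the assay and not a number, and the top of the read-out now holds more of the series: the limit of > 50000 nM in this assay, at which 2 of the 4 values shown sit.

The change removes the ring and its trifluoromethyl group and brings in tert-butyl all at once, so the compounds shown do not separate these parts; a cyclohexyl group or an unsubstituted phenyl on the same amide-type nitrogen would bear on that question. Also open, on these data alone, are the reading with an amine or a carboxylic acid carried on that nitrogen and the full size of the step, which cannot be told from a limit.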